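The source may hold more compounds than are shown below. What is called first, only, known or untested is meant among the compounds shown, and "the series" means these compounds.

Series notes on the shared core of compound 1 `O=C1NC(=O)C(Cc2ccc(Oc3ccc(Cl)cc3Cl)cc2C(F)(F)F)S1` and compound 2 `O=C1NC(=O)C(Cc2ccc(Oc3ncc(Cl)cc3Cl)cc2)S1`. In a functional assay for agonist activity at Free fatty acid receptor 1 (Homo sapiens), read by FLIPR, in the presence of a further agent that is not named here (on this read-out lower numbers stand for an effect already at smaller amounts and higher numbers for an effect only at larger amounts of compound), compound 1 gives 88 nM. In this assay compound 2 gives 90 nM. For the measured compounds named here, compound 1 has the lowest of the two numbers known so far; its nearest neighbour is compound 2, and the two values lie within the scatter of each other, so no order between them can be claimed. Going by the values given here, no step between two measured compounds that differ in one place is available from these two.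

The next compound, compound 3 `O=C1NC(=O)C(Cc2ccc(Oc3ccc(Cl)cc3Cl)cc2)S1`, is to be measured in this assay. It differs from compound 1 as follows: hydrogen in place of trifluoromethyl on an aromatic carbon. Among the compounds with values here, with no measured step on this core to lean on, the expected step from compound 1 to compound 3 is small, if anything toward a higher number, and likely within the scatter. The estimate for compound 3 in this assay is 140 nM, with a range from 45 nM to 450 nM, corresponding to an expected step of a 1.6-fold higher number from compound 1 to compound 3 (0.20 log units; within the scatter).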

Compound 3, half-maximal effective concentration: 101 nM
Compound 3: the middle estimate sits 1.4-fold (0.14 log units) above what was measured; the range from low to high includes it.
By their numbers in this assay, from the lowest: compounds 1, 2 and 3 (each within the scatter of the next).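

For the compounds shown here, this is the first measured step at this position, the aromatic carbon ortho to the (2,4-dioxo-1,3-thiazolidin-5-yl)methyl group and meta to the 2,4-dichlorophenoxy group: in this assay, hydrogen in place of trifluoromethyl gives a 1.1-fold higher number from compound 1 to compound 3 (0.06 log units; within the scatter). On this core, therefore, the read-out does not depend on the trifluoromethyl group, as its 4 heavy atoms can give way to a hydrogen atom without a difference beyond the scatter, though this rests on a single pair of compounds. No information is available on what lies behind this result.

Hydrogen and trifluoromethyl are the only two groups shown at this position, so it remains open whether a methoxy group, an amine, a carboxylic acid or a longer alkyl chain on the same aromatic carbon would also stay within the scatter of these two compounds. Also open, as far as these compounds go, is whether trifluoromethyl at this position would read the same on the core of compound 2, and whether the same holds for any read-out other than the half-maximal effective concentration in this assay.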